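Fluoro for (4-chlorophenyl)carbonyl on the shared core

The source may report more compounds than this note shows. Statements on the series, on what has been measured and on what is new or still open speak of the compounds shown alone.

Measured so far in an assay on HEK293 cells for inhibition of acid ceramidase (Homo sapiens), with a stated time of 10 min; a lower number here means a stronger inhibitor, a higher number a weaker inhibitor:
- compound 1, `O=C(c1ccc(Cl)cc1)c1ccc2c(c1)oc(=O)n2C(=O)NCCCCc1ccccc1`: 14 nM
- compound 2, `O=C(NCCCCc1ccccc1)n1c(=O)oc2cc(Cl)c(Cl)cc21`: 18 nM
- compound 3, `COc1ccc(-c2ccc3oc(=O)n(C(=O)NCCCCc4ccccc4)c3c2)cc1`: 67 nM

Compound 1 gives the lowest number of the three; compound 2 sits within the scatter of it, while compound 3 lies beyond the scatter at a higher number. Compound 4, `O=C(NCCCCc1ccccc1)n1c(=O)oc2cc(F)ccc21`, has not been measured. It differs from compound 1 in one place: fluoro in place of (4-chlorophenyl)carbonyl on an aromatic carbon. A much smaller group takes the place of the one that leaves. For the measured compounds named here, no measured pair tracks this change, so the expectation rests only on compound 1 and the spread among compounds 1 to 3. A weakening step is expected, a 6.4-fold higher number from compound 1 to compound 4 (0.81 log units; beyond the scatter), beyond the scatter. Compound 4 is estimated at 90 nM, in the range 25 nM to 350 nM.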

Compound 4, half-maximal inhibitory concentration: 31 nM
The estimate for compound 4 lay 2.9-fold (0.46 log units) above the measured number; the range from low to high includes it.
By their numbers in this assay, from the lowest: compounds 1, 2 and 4 (each within the scatter of the next, the first and the last beyond it); then compound 3.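

In this assay fluoro in place of (4-chlorophenyl)carbonyl on this aromatic carbon gives a 2.2-fold higher number from compound 1 to compound 4 (0.35 log units; beyond the scatter) and so costs only a modest amount. This position therefore keeps inhibition without the aromatic ring and carbonyl that leave, despite the much smaller group that enters. Nothing at hand accounts for the size of this step. Open, on these data alone, is how an amine or a carboxylic acid on this aromatic carbon would compare with fluoro. Also open, as far as these compounds go, is whether the carbonyl or the chlorophenyl ring accounts for the difference between the two compounds.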